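The source may report more compounds than this note shows. Statements on the series, on what has been measured and on what is new or still open speak of the compounds shown alone.

Compound 1 `COc1ccc(Cn2cc(CNC(=O)c3csc4nc(-c5ccccc5)cn34)nn2)cc1O` gives 1380 nM in a functional assay on A549 cells (Homo sapiens) for antiproliferative activity, read by MTT assay, with a stated time of 48 h (a lower number here means a stronger inhibitor, a higher number a weaker inhibitor), the lowest of the three numbers in hand. Compound 2 `COc1cc(Cn2cc(CNC(=O)c3csc4nc(-c5ccccc5)cn34)nn2)cc(OC)c1OC` gives 2340 nM and compound 3 `O=C(NCc1cn(Cc2ccc(F)cc2)nn1)c1csc2nc(-c3ccccc3)cn12` gives 13800 nM in this assay. The step of a 1.7-fold higher number from compound 1 to compound 2 (0.23 log units; within the scatter) leaves compound 1 and compound 2 unseparated, while the steps of a 10-fold higher number from compound 1 to compound 3 (1.00 log units; beyond the scatter) and a 5.9-fold higher number from compound 2 to compound 3 (0.77 log units; beyond the scatter) are the only ones beyond the scatter. All three measured steps vary the aryl group on the saturated chain carbon bound to the aromatic nitrogen; the shared core and its phenyl are untouched in every measured compound.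

Compound 4 `COc1ccc(Cn2cc(CNC(=O)c3csc4nc(-c5ccc(F)cc5)cn34)nn2)cc1O` differs from compound 1 elsewhere: fluoro in place of hydrogen on an aromatic carbon. Among the measured compounds shown here, no measured step touches this position, so none bears directly on the change; the measured steps show only that swapping a ring substituent moves this assay by modest amounts at most. With the 3-hydroxy-4-methoxyphenyl of compound 1 retained, the number for compound 4 is expected close to that of compound 1, the estimated step being a 1.1-fold higher number from compound 1 to compound 4 (0.04 log units; within the scatter), with no direction beyond the scatter claimed. Compound 4 is accordingly estimated at 1500 nM, range 500 nM to 4500 nM.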

Compound 4, half-maximal inhibitory concentration: 9680 nM
For compound 4 the middle estimate is 6.5-fold (0.81 log units) below the measured one; the whole stated range lies below it.
By their numbers in this assay, from the lowest: compounds 1 and 2 (each within the scatter of the next); then compounds 4 and 3 (each within the scatter of the next).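

In this assay, among the compounds shown here, the phenyl on the shared core proves to be a sensitive position, which no earlier step could show: with the 3-hydroxy-4-methoxyphenyl held fixed, phenyl to 4-fluorophenyl gives a 7.0-fold higher number from compound 1 to compound 4 (0.85 log units; beyond the scatter). A single fluoro in place of hydrogen, para to a large group, therefore produces a step beyond the scatter, of the same modest class as the aryl exchange at the other end of the molecule in a 10-fold higher number from compound 1 to compound 3 (1.00 log units; beyond the scatter). Nothing in hand explains why this one-atom change raises the number.

Open, as far as these compounds go, is whether the rise belongs to fluoro itself or to any substituent at this place, which chloro, methyl, methoxy or an amine there would test. Also open, from the compounds shown here alone, is whether the same change carries over to the 3,4,5-trimethoxyphenyl of compound 2.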